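The compounds below may be only part of what the source reports. "The series", "measured", "known", "first", "only" and "open" are said of these compounds alone.

Of the compounds shown here, three have so far been measured in an assay on HEK293 cells for inhibition of Fatty-acid amide hydrolase 1 (Homo sapiens), read by fluorescence; on this read-out lower numbers stand for stronger inhibition and higher numbers for weaker inhibition. Compound 1 `c1cc2c(ccn2C2COC2)cc1-c1ccc2oc(NC3CCCCC3)nc2c1` gives 579 nM, and compound 2 `NC(=O)Cn1ccc2cc(-c3ccc4oc(NC5CCCCC5)nc4c3)ccc21` gives 214 nM. Within the data shown here, the only single-point step between measured compounds, a 2.7-fold lower number from compound 1 to compound 2 (0.43 log units; beyond the scatter), is a modest one. Compound 3 `COc1ccc(Nc2nc3cc(-c4ccc5c(ccn5C)c4)ccc3o2)cc1` gives 280 nM, the second highest of the three numbers: its gap to compound 2 lies within the scatter, while compound 1 sits beyond it. Compound 4 `Cn1ccc2cc(-c3ccc4oc(N5Cc6cccnc6C5)nc4c3)ccc21` has not yet been measured; it differs from compound 3 by a group of 9 heavy atoms (7 carbon, 2 nitrogen; one five-membered non-aromatic ring with 1 hetero atom, one six-membered aromatic ring with 1 hetero atom) in place of a group of 9 heavy atoms (7 carbon, 1 nitrogen, 1 oxygen; one six-membered aromatic ring of carbon only), on an aromatic carbon. Among the measured compounds shown here, none of the measured steps touches this part of the shared core, so the one known step offers no guide. The change expected for compound 4 is therefore a 1.1-fold higher number from compound 3 to compound 4 (0.03 log units; within the scatter), nothing beyond the scatter. Compound 4 is estimated at 300 nM, with a wide range from 90 nM to 1000 nM.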

Compound 4, half-maximal inhibitory concentration: 211 nM
Compound 4: the middle estimate sits 1.4-fold (0.15 log units) above what was measured, and the stated range covers the measured number.
By their numbers in this assay, from the lowest: compounds 4, 2 and 3 (each within the scatter of the next); then compound 1.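

In this assay, replacing the (4-methoxyphenyl)amino group with the group holding a five-membered non-aromatic ring and a six-membered aromatic ring gives a 1.3-fold lower number from compound 3 to compound 4 (0.12 log units; within the scatter), so the two cannot be told apart. This place on the shared core, on an aromatic carbon next to the ring nitrogen and next to the ring oxygen, therefore accepts a group with 0 hydrogen-bond donors in place of one with 1 hydrogen-bond donor, with no change beyond the scatter. On these data alone, whether a plain amine or a morpholine ring at this place would read the same stays open. Nothing available here explains why these two groups give such similar numbers.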